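A few compounds are considered here, and "the series" means these few. Any claim that something is new, unique, unknown or untested is made for them only; others in the source may bear on it.

The three measured compounds share one core, a hydrazide carrying a tert-butyl group and two acyl arms. Compound 2 `CC(C)(C)N(NC(=O)c1ccccc1Br)C(=O)c1ccccc1Cl` gives 316 nM in an assay on cells for agonist activity at ecdysone receptor (Bombyx mori), read by a luciferase reporter, with a stated time of 24 h (a lower number here means that less compound is needed, a higher number that more compound is needed for the effect), the highest of the three numbers. Compound 1 `Cc1cc(C)cc(C(=O)N(NC(=O)c2ccccc2)C(C)(C)C)c1` gives 69.2 nM in this assay, and compound 3 `CCCc1ccc(C(=O)NN(C(=O)c2ccccc2Cl)C(C)(C)C)cc1` gives 9.12 nM, both lower than compound 2 and both separated from it by more than the usual scatter, compound 3 by the wider margin.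

Compound 4 `Cc1ccc(C(=O)NN(C(=O)c2ccccc2Cl)C(C)(C)C)c(C)c1` has not been measured. It differs from compound 2 in one place: 2,4-dimethylphenyl in place of 2-bromophenyl on a carbonyl carbon. Compound 4 keeps the chlorinated arm of compound 2 and of compound 3, and takes a methylated arm of the kind that compound 1 carries, though with the methyl groups arranged differently. Because compound 3 gives 9.12 nM with the same chlorinated arm, a move toward lower numbers is expected, of the size a 7.9-fold lower number from compound 2 to compound 4 (0.90 log units; beyond the scatter), beyond the scatter. Compound 4 is therefore estimated at 40 nM, with a range from 8 nM to 200 nM.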

Compound 4, half-maximal effective concentration: 162 nM
Compound 4: middle estimate off by 4.1-fold (0.61 log units), on the low side; low and high end bracket the measured number.
By their numbers in this assay, from the lowest: compound 3; then compound 1; then compounds 4 and 2 (each within the scatter of the next).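

In this assay, putting 2,4-dimethylphenyl in place of 2-bromophenyl on a carbonyl carbon gives a 2.0-fold lower number from compound 2 to compound 4 (0.29 log units; within the scatter), so this particular exchange does not separate the two compounds, even though a bromine-bearing ring gives way to one carrying only carbon. The chlorinated arm alone also does not set the number: with that arm in place, compound 4 gives 162 nM, whereas compound 3, which has a propyl-bearing ring at this position, gives 9.12 nM. No measurement on hand explains why these rings behave as they do.

From the compounds shown here alone, it remains open whether a ring at this position carrying a methoxy group, an amine or a carboxylic acid would shift the number beyond the scatter. Going by these compounds, it is also open how a propyl chain compares with a longer chain there.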